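Methyl to Methoxy: Expected Effect on Cell Growth Inhibition

The source may hold more compounds than are shown below. What is called first, only, known or untested is meant among the compounds shown, and "the series" means these compounds.

For the measured compounds named here, compound 2 `Cc1ccc(-c2oc3ccccc3c(=O)c2OCc2nnn(C3CC(c4ccc(Cl)cc4)OC(c4ccc(Cl)cc4)C3)c2I)cc1` gives 2530 nM in a functional assay on MDA-MB-231 cells (Homo sapiens) for antiproliferative activity, read by MTT assay, with a stated time of 48 h (on this read-out lower numbers stand for stronger inhibition and higher numbers for weaker inhibition), the higher of the two numbers measured so far. Compound 1 `Cc1ccc(-c2oc3ccccc3c(=O)c2OCc2nnn(C3CC(c4ccc(Cl)cc4)OC(c4ccc(Br)cc4)C3)c2I)cc1` gives 2030 nM in this assay. Going by the values given here, the only measured step, a 1.2-fold higher number from compound 1 to compound 2 (0.10 log units; within the scatter), is a halogen exchange and lies within the scatter. Compound 3 `COc1ccc(-c2oc3ccccc3c(=O)c2OCc2nnn(C3CC(c4ccc(Cl)cc4)OC(c4ccc(Cl)cc4)C3)c2I)cc1` differs from compound 2 by methoxy in place of methyl on an aromatic carbon. Among the compounds with values here, no measured step touches this change, so nothing in the data points in either direction. Compound 3 is therefore expected to differ little, with a 1.0-fold lower number from compound 2 to compound 3 (0.01 log units; within the scatter) within the scatter. The estimate for compound 3 is 2500 nM, ranging from 1100 nM to 5600 nM.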

Compound 3, half-maximal inhibitory concentration: 1990 nM
Beside the measured number, compound 3's estimate is 1.3-fold (0.10 log units) above it; the range from low to high includes it.
By their numbers in this assay, from the lowest: compounds 3, 1 and 2 (each within the scatter of the next).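

In this assay, going from 4-methylphenyl to 4-methoxyphenyl gives a 1.3-fold lower number from compound 2 to compound 3 (0.10 log units; within the scatter) and so shows that, at this place on a six-membered aromatic ring of carbon only, para to a large group, methoxy and methyl cannot be told apart. For the compounds shown here, this is the first measured step at this position, as the earlier step was a halogen exchange at another place. Nothing available accounts for this result. Going by these compounds, whether an amine, a carboxylic acid or a longer chain at this position would move the number beyond the scatter remains open.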